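The source may hold more compounds than are shown below. What is called first, only, known or untested is meant among the compounds shown, and "the series" means these compounds.

The study gathers three compounds built on a shared core. Within the data shown here, compound 1 `Cc1ccc2oc(=O)cc(Cn3cc(Cn4cnc5c4c(=O)n(C)c(=O)n5C)nn3)c2c1` is the only one with a number in an ADME assay on HEK293 cells (Homo sapiens) for cytotoxicity, read by MTT assay, with a stated time of 48 h (on this read-out higher numbers stand for weaker inhibition and lower numbers for stronger inhibition), where compound 1 gives 1110000 nM. Compound 2 `Cc1cc(C)c2c(Cn3cc(Cn4cnc5c4c(=O)n(C)c(=O)n5C)nn3)cc(=O)oc2c1` was also entered in this assay, but for compound 2 the outcome is recorded as "not determined" (no result reported), so no number is known for it. Compound 1 therefore stands alone on the numbers shown, with nothing to rank it against. Compound 3 `COc1ccc2oc(=O)cc(Cn3cc(Cn4cnc5c4c(=O)n(C)c(=O)n5C)nn3)c2c1` remains to be measured in this assay. The change from compound 1 to compound 3 is methoxy in place of methyl on an aromatic carbon. Among the measured compounds shown here, no step between measured compounds is available to guide an expectation, so the size of the change can only be guessed. For the measured compounds named here, since the sole value, that of compound 1 at 1110000 nM, lies far from any sign of strong inhibition, the step of a 1.1-fold lower number from compound 1 to compound 3 (0.05 log units; within the scatter) is expected to stay within the usual scatter, in no particular direction. Compound 3 is estimated to give 1000000 nM in this assay, with a range from 400000 nM to 3000000 nM.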

Compound 3, half-maximal inhibitory concentration: 1380000 nM
The estimate for compound 3 lay 1.4-fold (0.14 log units) below the measured number, and the stated range covers the measured number.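

With compound 3 the study gains its first pair of numbers, and methoxy in place of methyl on this aromatic carbon, meta to a fused ring and para to a fused ring, gives a 1.2-fold higher number from compound 1 to compound 3 (0.09 log units; within the scatter) in this assay on the shared core. Among these compounds, on this single pair, the read-out does not separate methoxy from methyl at this place, something the earlier compounds could not show, since only one of them carried a number. No measurement at hand bears on why the two groups read alike.

What the compounds shown leave open is whether this holds only for methyl and methoxy or also for quite different groups on the same carbon, such as an amine, a carboxylic acid or a longer chain. Compound 2 has no number in this assay and so adds nothing to the comparison, and whether any group at this place could move the read-out beyond the scatter remains unanswered.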